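The compounds below may be only part of what the source reports. "The series", "measured", "known", "first", "only" and "open" are said of these compounds alone.

Compound 1 `CCn1c(C(=O)NCCN)ccc1C(CC)(CC)c1ccc(OCCC(O)(CC)CC)c(C)c1`: 670 nM
Compound 2 `CCn1c(C(=O)N(CCC#N)CCC#N)ccc1C(CC)(CC)c1ccc(OCCC(O)(CC)CC)c(C)c1`: > 50000 nM (a limit)
Compound 3 `CCOc1ccc(NC(=O)c2ccc(C(CC)(CC)c3ccc(OCCC(O)(CC)CC)c(C)c3)n2CC)cc1`: > 50000 nM (a limit)

These compounds were tested in a functional assay on MCF7 cells (Homo sapiens) for antiproliferative activity, read by MTT assay, with a stated time of 48 h; a lower number here means a stronger inhibitor, a higher number a weaker inhibitor. Among the measured compounds shown here, compound 1 is the only one with a measured number. Compound 2 stands at the limit of > 50000 nM in this assay, at which 2 of the 3 values shown sit, so it has a limit and not a number.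

Compound 4 `CCC(C)C(NC(=O)c1ccc(C(CC)(CC)c2ccc(OCCC(O)(CC)CC)c(C)c2)n1CC)C(=O)OC` keeps the shared core and differs from compound 2 in one place: a group of 10 heavy atoms (7 carbon, 1 nitrogen, 2 oxygen; no ring) in place of a group of 9 heavy atoms (6 carbon, 3 nitrogen; no ring), on a carbonyl carbon.

The measured steps that bear on this change both start from compound 1 and remove its 2-aminoethyl group, which compound 4 also lacks. The first is an at least 74-fold higher number from compound 1 to compound 2 (1.87 log units; beyond the scatter). The second is an at least 74-fold higher number from compound 1 to compound 3 (1.87 log units; beyond the scatter). Both are large, while a step that the two limits leave unreadable from compound 2 to compound 3 cannot be read. Compound 4 is therefore expected to stay weak in this assay, near that limit. No clear change in either direction is expected, and the estimated step is an at least 1.1-fold lower number from compound 2 to compound 4 (0.04 log units; that floor lies within the scatter). The estimated value for compound 4 is 45000 nM, with an expected range of 12000 nM to 90000 nM.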

Compound 4, half-maximal inhibitory concentration: > 50000 nM
Compound 4: a limit, no number; the forecaster's own chance of this, stated with the estimate: 60%; middle value at least 1.1-fold (0.04 log units) away from the limit.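

Compound 4 also gives only a limit, not a number, in this assay, and it joins compound 2 and compound 3 there: the limit of > 50000 nM in this assay, at which 3 of the 4 values shown sit.

On the amide-type nitrogen, the step is an at least 74-fold higher number from compound 1 to compound 4 (1.87 log units; beyond the scatter). Compound 4 keeps the amide hydrogen that compound 2 lacks and carries no ring, unlike compound 3, so neither of those two differences is needed for a compound to sit at the limit. The steps among compound 2, compound 3 and compound 4 cannot be read, since both ends of each are limits.

From the compounds shown here alone, only compound 1 has a measured number, so it stays open whether the amine of its 2-aminoethyl group matters or the chain as a whole. A 2-hydroxyethyl group or a 3-aminopropyl chain on the same nitrogen would separate these two readings.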